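A few compounds are considered here, and "the series" means these few. Any claim that something is new, unique, unknown or untested is made for them only; others in the source may bear on it.

Working notes on the series. Three compounds of the shared core have numbers in a functional assay for agonist activity at G protein-coupled receptor 88 (Homo sapiens), read by HTRF and cAMP accumulation; a lower number here means that less compound is needed, a higher number that more compound is needed for the effect. Compound 1 `CC[C@H](C)[C@H](N)CN(C(=O)[C@@H]1C[C@H]1c1cccc(C#N)c1)c1ccc(-c2ccccc2)cc1` gives 1600 nM in this assay. Compound 2 `Cc1ccc(-c2ccc(N(C[C@@H](N)CC(C)C)C(=O)[C@@H]3C[C@H]3c3ccccc3)cc2)cc1` gives 360 nM in this assay. Going by the values given here, compound 3 `CCCc1ccc(-c2ccc(N(C[C@@H](N)[C@@H](C)CC)C(=O)[C@@H]3C[C@H]3c3ccccc3)cc2)cc1` gives 61 nM in this assay, the lowest of the three; its gaps to compound 2 and to compound 1 both lie beyond the usual scatter, so compound 3 is the most potent compound measured so far. Among the compounds with values here, no pair of these three differs in a single place, so no single step is isolated among them.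

Compound 4 `CC[C@H](C)[C@H](N)CN(C(=O)[C@@H]1C[C@H]1c1ccccc1)c1ccc(-c2ccc(CCC(=O)OC)cc2)cc1` is not yet measured. It differs from compound 3 in one place: methoxycarbonyl in place of methyl on a saturated chain carbon, two bonds along the chain from an aromatic carbon. The change sits in the propyl chain of compound 3, giving the 4-(2-(methoxycarbonyl)ethyl)phenyl end of compound 4. Nothing in the measured set shows the effect of this exchange, so the step is an expectation only. In this assay a modest weakening is expected, from compound 3 to compound 4 of about a 2.5-fold higher number from compound 3 to compound 4 (0.39 log units; beyond the scatter), though a result within the scatter would not surprise. Compound 4 is therefore estimated at 150 nM in this assay, with a range from 40 nM to 600 nM.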

Compound 4, half-maximal effective concentration: 110 nM
Compound 4: middle estimate off by 1.4-fold (0.13 log units), on the high side; the range from low to high includes it.
By their numbers in this assay, from the lowest: compounds 3 and 4 (each within the scatter of the next); then compound 2; then compound 1.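

In this assay, methoxycarbonyl in place of methyl on a saturated chain carbon, two bonds along the chain from an aromatic carbon, gives a step that is small (a 1.8-fold higher number from compound 3 to compound 4 (0.26 log units; within the scatter)). Going by these compounds alone, this is the first single-place step, and it shows that the propyl chain can become 2-(methoxycarbonyl)ethyl, adding two hydrogen-bond acceptors and a double bond, with no change beyond the scatter. No measured property bears on this result, so the size of the step remains unexplained.

On these data alone, whether the same position also accepts a carboxylic acid, an amine or a longer chain remains open. As far as these compounds go, it is also open whether this exchange would give a similar step with different groups elsewhere on the shared core.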